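Removing the phenyl from compound 2: expected tolerance

This account rests on a few compounds, and the source may have more. Where it says the series, first, only, none or still open, it means among the compounds named here.

Working notes on tolerance in an ADME assay on Vero cells (Chlorocebus sabaeus) for cytotoxicity, read by sulforhodamine B assay, with a stated time of 3 days; a lower number here means that less compound is tolerated, a higher number that more compound is tolerated. Compound 1 `CC1=C(C(=O)Nc2ccc(Cl)cc2)C(C/C=C/c2ccccc2)C(C(=O)Nc2ccc(Cl)cc2)=C(C)N1` gives 21 ug/mL; compound 3 `COc1ccc(NC(=O)C2=C(C)NC(=S)NC2c2cccc([N+](=O)[O-])c2)cc1` gives 80 ug/mL; compound 2 `COc1ccc(NC(=O)C2=C(C)NC(=O)NC2c2ccccc2)cc1` gives 225 ug/mL, the highest of the three numbers, with compound 3 nearest and compound 1 furthest, both gaps beyond the scatter. Compound 4 `COc1ccc(NC(=O)C2=C(C)NC(=O)NC2)cc1` has not yet been measured in this assay. It differs from compound 2 in one place: hydrogen in place of phenyl on a saturated ring carbon. Among the measured compounds shown here, no step between measured compounds bears on this change, so the expectation rests on compound 2 alone. The step is expected to be small, either slightly upward or none beyond the scatter, as a 1.3-fold higher number from compound 2 to compound 4 (0.12 log units; within the scatter). Compound 4 is therefore estimated to give 300 ug/mL, within a range from 120 ug/mL to 700 ug/mL.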

Compound 4, half-maximal cytotoxic concentration: 200 ug/mL
The estimate for compound 4 lay 1.5-fold (0.18 log units) above the measured number, and the stated range covers the measured number.
By their numbers in this assay, from the lowest: compound 1; then compound 3; then compounds 4 and 2 (each within the scatter of the next).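

In this assay, hydrogen in place of phenyl on this saturated ring carbon gives a 1.1-fold lower number from compound 2 to compound 4 (0.05 log units; within the scatter) and so leaves tolerance unchanged for this pair. Compound 1 and compound 3 each differ from compound 2 in more than one place, so neither could show that the phenyl can be lost here without a step beyond the scatter. No measurement at hand bears on the reason for this result.

On these data alone, whether an amine, a carboxylic acid or a longer chain on this carbon would also leave the number unchanged stays open. So does whether the same change behaves alike on the core of compound 3.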